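The compounds below may be only part of what the source reports. "The series", "measured", "known", "first", "only" and "open" are said of these compounds alone.

Measured so far:
compound 1 `CC(C)NCCS(=O)(=O)NC(=O)c1ccc(Nc2nc(NC3(c4ccc(Cl)cc4)CC3)nc(OCC(F)(F)F)n2)cc1`: 89%
compound 2 `CCCCCNc1nc(Nc2ccc([N+](=O)[O-])cc2)nc(OCC(F)(F)F)n1`: 74%

In an ADME assay on microsomes from liver (Homo sapiens) for metabolic stability, with a stated time of 10 min (on this read-out higher numbers stand for a more stable compound and lower numbers for a less stable compound), compound 1 gives 89%, the higher of the two numbers shown. Compound 2 gives 74%, a number that lies beyond the scatter below compound 1. Compound 3 `CC(C)(C)CNCCS(=O)(=O)NC(=O)c1ccc(Nc2nc(NC3(c4ccc(Cl)cc4)CC3)nc(OCC(F)(F)F)n2)cc1` differs from compound 1 only by neopentyl in place of isopropyl on an amine nitrogen. Among the measured compounds shown here, no measured pair shows this change, so its size is not known from these data. Compound 1 already stands high, and the step of a number 5 percentage points lower from compound 1 to compound 3 (within the scatter) is expected to be small, at most a modest drop. Compound 3 is therefore expected to give 84%, with a range from 70% to 95%.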

Compound 3, percent of the compound remaining: 89%
The estimate for compound 3 lay 5 percentage points below the measured number, and the stated range covers the measured number.
By their numbers in this assay, from the lowest: compound 2; then compounds 1 and 3 (each within the scatter of the next).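

In this assay, putting neopentyl in place of isopropyl on the amine nitrogen gives no change at the digits printed from compound 1 to compound 3 (within the scatter). Among the compounds shown here, this is the first measured change at this position, and it shows that the read-out stays put when the group grows from 3 to 5 carbon atoms. Nothing measured here explains why.

One step at one position cannot show how far this holds. A carboxylic acid, a phenyl ring or a longer straight chain on this nitrogen could give a different number, as could neopentyl on another core.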